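Removing the sulfonyl: compound 4 in the antiproliferative series

The compounds below may be only part of what the source reports. "The series", "measured", "known", "first", "only" and "open" are said of these compounds alone.

Measured compounds:
compound 1 `CC(=O)c1ccc(S(=O)(=O)N[C@@H](C)Cn2ccc(-c3ccc(C#N)c(Cl)c3)n2)cc1`, 5230 nM
compound 2 `C[C@@H](Cn1ccc(-c2ccc(C#N)c(Cl)c2)n1)NS(=O)(=O)c1cccnc1`, 6140 nM
compound 3 `C[C@@H](Cn1ccc(-c2cc(F)c(C#N)c(Cl)c2)n1)NC(=O)Nc1cc(C(C)(C)C)[nH]n1`, 1630 nM

In a functional assay on LNCaP cells (Homo sapiens) for antiproliferative activity, read by CCK-8 assay, with a stated time of 6 days (a lower number here means a stronger inhibitor, a higher number a weaker inhibitor), compound 2 stands highest of the three numbers; against compound 1 its step, a 1.2-fold higher number from compound 1 to compound 2 (0.07 log units; within the scatter), is within the scatter, while compound 3 gives the lowest number, beyond the scatter from compound 2. Compound 4 `C[C@@H](Cn1ccc(-c2ccc(C#N)c(Cl)c2)n1)Nc1ccncc1` is not yet measured. It differs from compound 2 by pyridin-4-yl in place of (pyridin-3-yl)sulfonyl on an amine nitrogen. Among the measured compounds shown here, the only measured step, a 1.2-fold higher number from compound 1 to compound 2 (0.07 log units; within the scatter), swaps one aryl for another on the retained sulfonyl and says nothing about losing the sulfonyl itself; compound 3 differs in several places at once. For the measured compounds named here, no measured step therefore bears on this change, and no shift beyond the scatter is expected. Compound 4 is estimated at 5500 nM, range 1500 nM to 20000 nM, a step of a 1.1-fold lower number from compound 2 to compound 4 (0.05 log units; within the scatter).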

Compound 4, half-maximal inhibitory concentration: 2560 nM
Compound 4: the middle estimate sits 2.1-fold (0.33 log units) above what was measured; the range from low to high includes it.
By their numbers in this assay, from the lowest: compounds 3 and 4 (each within the scatter of the next); then compounds 1 and 2 (each within the scatter of the next).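

In this assay the sulfonyl proves dispensable on this amine nitrogen, with pyridin-4-yl in its place giving a 2.4-fold lower number from compound 2 to compound 4 (0.38 log units; beyond the scatter) as a modest step beyond the scatter. Unlike the aryl swap on the retained sulfonyl, this step removes the sulfonyl and activity is not lost. Nothing measured accounts for the shift. The step also moves the pyridine attachment, so the contribution of sulfonyl loss remains separate and unresolved. Going by these compounds, whether a simple ethyl chain on this amine nitrogen can stand in for the aromatic ring also remains open.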